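The source may report more compounds than this note shows. Statements on the series, on what has been measured and on what is new or still open speak of the compounds shown alone.

In a physicochemical assay for solubility, at pH 6.8 (a lower number here means a less soluble compound, a higher number a more soluble compound), compound 1 `O=[N+]([O-])c1cn2c(n1)OC[C@@H](NCc1ccc(OC(F)(F)F)c(Oc3ccccc3)c1)C2` gives < 2 ug/mL, which is a limit of the assay and not a number. Compound 2 `O=[N+]([O-])c1cn2c(n1)OC[C@@H](NCc1ccc(OC(F)(F)F)cc1O)C2` gives a measured 25 ug/mL in this assay. Compound 3 `O=[N+]([O-])c1cn2c(n1)OC[C@@H](NCc1ccc(OC(F)(F)F)c(F)c1)C2` has fluoro in place of phenoxy on an aromatic carbon, ortho to a trifluoromethoxy group: fluoro in place of phenoxy on an aromatic carbon. No measured step sizes this change, so the expectation leans only on compound 2 at 25 ug/mL. An upward step beyond the scatter is expected in this assay, estimated as an at least 5.0-fold higher number from compound 1 to compound 3 (0.69 log units; beyond the scatter). For compound 3 the estimated value is 10 ug/mL, with an expected range of 3 ug/mL to 40 ug/mL.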

Compound 3, solubility: 43 ug/mL
Compound 3: the middle estimate sits 4.3-fold (0.63 log units) below what was measured; measured number outside the range, above it.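

In this assay, going by these compounds alone, fluoro in place of phenoxy on an aromatic carbon, ortho to a trifluoromethoxy group, gives an at least 21-fold higher number from compound 1 to compound 3 (1.33 log units; beyond the scatter) and is the first sized change at this position. The read-out at this position therefore responds strongly to this swap. The true size remains unknown because the value for compound 1 is a limit and not a number: the limit of < 2 ug/mL in this assay, at which 1 of the 3 values shown sits.

As far as these compounds go, whether the rise follows from the loss of phenoxy or from the presence of fluoro stays open. In this assay, from the compounds shown here alone, the reading of an amine or a carboxylic acid on this aromatic carbon also stays open.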